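Cyano on the phenyl ring: expected cytotoxicity of compound 4

The source may report more compounds than this note shows. Statements on the series, on what has been measured and on what is new or still open speak of the compounds shown alone.

Compound 1, `C/C(=C\c1cc(C2=CCCC2)co1)C(N)=O`, in an ADME assay on NIH3T3 cells (Mus musculus) for cytotoxicity, read by CCK-8 assay, with a stated time of 24 h; on this read-out higher numbers stand for weaker inhibition and lower numbers for stronger inhibition: 49300 nM.
Compound 2, `C/C(=C\c1cc(-c2ccccc2)cs1)C(N)=O`, in this assay: > 50000 nM, which is a limit of the assay and not a number.
Compound 3, `C/C(=C\c1cc(-c2ccccc2C)cs1)C(N)=O`, in this assay: > 50000 nM, again a limit of the assay.

For the measured compounds named here, compound 2 therefore stands at the upper edge of what the assay reports; the only numerical value in the set, that of compound 1, sits close to that edge. Going by the values given here, the one measured step that changes the phenyl ring, a step that the two limits leave unreadable from compound 2 to compound 3, gives no readable size, since both ends are limits, as the limit of > 50000 nM in this assay, at which 2 of the 3 values shown sit, shows.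

Compound 4, `C/C(=C\c1cc(-c2ccc(C#N)cc2)cs1)C(N)=O`, differs from compound 2 by cyano in place of hydrogen on an aromatic carbon. Among the compounds with values here, no measured step carries a cyano group, so the only guide is that the single measured change on the same ring left compound 3 at the limit. The expected step in this assay from compound 2 to compound 4 is a number no higher from compound 2 to compound 4 (the limit leaves the size open), that is, none beyond the scatter. Compound 4 is therefore estimated at 50000 nM, with a plausible range from 25000 nM to 100000 nM, and most likely reported only as a limit.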

Compound 4, half-maximal inhibitory concentration: > 50000 nM
Compound 4 was reported as a limit (the forecaster's own chance of this, stated with the estimate: 70%); the middle value sits exactly at the limit.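

In this assay compound 4 gives > 50000 nM, a limit of the assay and not a number. Compound 2 is likewise reported only as a limit, so no size can be read for the step from compound 2 to compound 4: the limit of > 50000 nM in this assay, at which 3 of the 4 values shown sit.

The compounds shown leave open whether cyano in place of hydrogen changes cytotoxicity at all.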